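The source may report more compounds than this note shows. Statements on the series, on what has been measured and on what is new or still open speak of the compounds shown alone.

Compound 1 `COc1ccc(C2CC(c3ccc4ccccc4c3)=NN2C2=NC(=O)/C(=C3\C(=O)Nc4ccccc43)S2)cc1` and compound 2 `COc1ccc(C2CC(c3ccc4ccccc4c3)=NN2C2=NC(=O)/C(=C3\C(=O)Nc4ccc(Br)cc43)S2)cc1` share one core; in a functional assay on cells (Cancer cell lines, Homo sapiens) for cytotoxicity, read by sulforhodamine B assay, with a stated time of 48 h (on this read-out higher numbers stand for weaker inhibition of growth and lower numbers for stronger inhibition of growth), compound 1 gives 970 nM and compound 2 gives 110 nM. The change between them is bromo in place of hydrogen on an aromatic carbon, and it brought an 8.8-fold lower number from compound 1 to compound 2 (0.95 log units; beyond the scatter). Compound 3 `COc1ccc(C2=NN(C3=NC(=O)/C(=C4\C(=O)Nc5ccccc54)S3)C(c3ccc(Cl)cc3)C2)cc1` has a different core; the difference between the two cores is not broken down here. In this assay compound 3 gives 100000 nM, the highest of the three numbers, far weaker than either compound 1 or compound 2. Compound 4 `COc1ccc(C2=NN(C3=NC(=O)/C(=C4\C(=O)Nc5ccc(Br)cc54)S3)C(c3ccc(Cl)cc3)C2)cc1` is derived from compound 3 by bromo in place of hydrogen on an aromatic carbon, the same change that was made from compound 1 to compound 2, with the bromo entering at the same kind of place, meta to a fused ring and para to a fused ring. Among the measured compounds shown here, for compound 4 the step is expected to be a 3.3-fold lower number from compound 3 to compound 4 (0.52 log units; beyond the scatter), resting only on the earlier step, because the size of an 8.8-fold lower number from compound 1 to compound 2 (0.95 log units; beyond the scatter) is the single precedent, and starting from a much weaker parent the gain may be smaller or the assay may report only a limit. The estimate for compound 4 is 30000 nM, between 8000 nM and 100000 nM.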

Compound 4, concentration for 50% growth inhibition: 190 nM
Estimate against measurement, compound 4: 160-fold (2.20 log units) above; the whole stated range lies above it.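

Bromo in place of hydrogen on an aromatic carbon gave a 530-fold lower number from compound 3 to compound 4 (2.72 log units; beyond the scatter) in this assay, which makes compound 4 far stronger in growth inhibition than its parent. Set beside the earlier step, the change lowered the number on both cores, but its size did not carry from one core to the other: the same change on two cores in this assay, an 8.8-fold lower number (0.95 log units; beyond the scatter) from compound 1 to compound 2 and a 530-fold lower number (2.72 log units; beyond the scatter) from compound 3 to compound 4, 60-fold (1.78 log units) apart, beyond the scatter of two such steps With only one pair on each core, this shows that the direction held in these two cases, but it does not show what sets the size of the step, since the difference between the two cores is not broken down and nothing here ties the gap to any part of it.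

What the compounds shown leave open is whether chloro, a methyl group or an amine at this place would bring a gain like that of bromo on either core. Also open, going by these compounds, is whether the same change would lower the number on a third core, and by how much.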